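Solubility of a Tetrahydroisoquinoline Analogue in a Diketopiperazine Series

This account rests on a few compounds, and the source may have more. Where it says the series, first, only, none or still open, it means among the compounds named here.

Of the compounds shown here, two sharing one core have been measured in a physicochemical assay for solubility, read by spectrophotometry, in phosphate buffer, with a stated time of 2 h, at pH 7.4; on this read-out higher numbers stand for higher solubility and lower numbers for lower solubility. Compound 1 `COc1cccc(CN2C(=O)CN(C(=O)c3cc4cc(OC)ccc4[nH]3)C[C@@H]2COCc2ccccc2)c1` gives 11700 nM in this assay, while compound 2 `COc1ccc2[nH]c(C(=O)N3CC(=O)N(Cc4ccccc4)[C@@H](N4[C@H](C)CCC[C@@H]4C)C3)cc2c1` gives 100000 nM. Compound 2 therefore holds the higher of the two numbers, and the gap to compound 1 is beyond the scatter of the method, so compound 2 is the more soluble of the pair as measured.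

Compound 3 `COc1ccc2[nH]c(C(=O)N3CC(=O)N(Cc4ccccc4)[C@@H](CN4CCc5ccccc5C4)C3)cc2c1` is the next compound to be measured in this assay. It differs from compound 2 in a single position: (1,2,3,4-tetrahydroisoquinolin-2-yl)methyl in place of 2,6-dimethylpiperidin-1-yl on a saturated ring carbon. The group that enters is larger by heavy-atom count and brings an additional six-membered aromatic ring of carbon only, while the group that leaves carries two defined stereocentres and no aromatic ring.

Going by the values given here, no step between two measured compounds describes this particular change, so the expectation rests on the values of compound 2 and compound 1 alone. Compound 3 is expected to fall below compound 2, with a step of a 3.3-fold lower number from compound 2 to compound 3 (0.52 log units; beyond the scatter) that is expected to lie beyond the scatter. The estimate for compound 3 in this assay is 30000 nM, with a range from 8000 nM to 100000 nM.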

Compound 3, solubility: 9000 nM
Beside the measured number, compound 3's estimate is 3.3-fold (0.52 log units) above it; low and high end bracket the measured number.
By their numbers in this assay, from the lowest: compounds 3 and 1 (each within the scatter of the next); then compound 2.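

In this assay, exchanging the group on this saturated ring carbon, the one next to the ring atom that bears a benzyl group, gives an 11-fold lower number from compound 2 to compound 3 (1.05 log units; beyond the scatter), which shows that the read-out depends strongly on what this position carries when the rest of the molecule stays the same. The change is a composite one: the entering group brings a six-membered aromatic ring of carbon only and a methylene link, and the defined stereocentres of the leaving group disappear, while the hydrogen-bond donor and acceptor counts of the group stay the same. No measurement available here bears on why the number moves, and the single step cannot divide its size among these differences.

The compounds shown leave open which of these differences matters, since a piperidin-1-ylmethyl group on the same carbon would keep the methylene link without the aromatic ring. They also leave open how the position responds to a group of another kind, such as a morpholine or a carboxylic acid.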